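The source may hold more compounds than are shown below. What is called first, only, known or untested is meant among the compounds shown, and "the series" means these compounds.

In a functional assay on NCI-H1975 cells (Homo sapiens) for cytotoxicity, read by MTT assay, with a stated time of 72 h (a higher number here means a weaker inhibitor, a lower number a stronger inhibitor), compound 1 `COc1cc(/C=C2\CNC/C(=C\c3cc(OC)c(OC)c(OC)c3)C2=O)cc(OC)c1OC` gives 4000 nM. Compound 2 `COc1cc(/C=C2\CN(C(=O)CCC(=O)O)C/C(=C\c3cc(OC)c(OC)c(OC)c3)C2=O)cc(OC)c1OC` gives > 60000 nM, and this is a limit of the assay, not a number. Compound 2 therefore has no exact position on the scale, and it is the only one of the two measured compounds at the limit of > 60000 nM in this assay, at which 1 of the 2 values shown sits. Compound 3 `CCC(=O)N1C/C(=C\c2cc(OC)c(OC)c(OC)c2)C(=O)/C(=C/c2cc(OC)c(OC)c(OC)c2)C1` differs from it by hydrogen in place of carboxy on a saturated chain carbon, two bonds along the chain from a carbonyl carbon, so that (2-carboxyethyl)carbonyl becomes propanoyl. Among the compounds with values here, one measured step bears on this change, the large rise an at least 15-fold higher number from compound 1 to compound 2 (1.17 log units; beyond the scatter), which introduced the carboxy along with the rest of that chain. Removing the carboxy alone might undo much of that rise, so a large move towards a lower number is expected. The expected step is an at least 15-fold lower number from compound 2 to compound 3 (1.17 log units; beyond the scatter). For compound 3 the estimated value is 4000 nM, within a range of 600 nM to 25000 nM.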

Compound 3, half-maximal inhibitory concentration: 1700 nM
Estimate against measurement, compound 3: 2.4-fold (0.37 log units) above, within the range that was stated.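

In this assay, the carboxy group alone turns out to carry the loss seen on extending the chain, since replacing it with hydrogen gives an at least 35-fold lower number from compound 2 to compound 3 (1.54 log units; beyond the scatter). On these data alone, compound 2 stands at a limit of the assay and not at an exact number, so the full size of that step stays unknown: the limit of > 60000 nM in this assay, at which 1 of the 3 values shown sits. The rest of the chain does no harm, for propanoyl in place of hydrogen on the amine nitrogen in the ring gives a 2.4-fold lower number from compound 1 to compound 3 (0.37 log units; beyond the scatter), a modest move towards a stronger inhibitor.

The compounds shown leave open whether a longer chain such as butanoyl would go on lowering the number, and whether a methyl ester in place of the carboxy would behave like compound 2 or compound 3. They also cannot tell why the carboxy costs so much.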